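Swapping the aryl arm for a cyclopentyl on the quinazoline core

The source may report more compounds than this note shows. Statements on the series, on what has been measured and on what is new or still open speak of the compounds shown alone.

Compound 3 `CCc1ccccc1-c1nc(NCc2ccc(-c3cccnc3)cc2)c2ccccc2n1` gives 780 nM in an assay on a protein complex for inhibition of ubiquitin carboxyl-terminal hydrolase 1/WD repeat-containing protein 48 (Homo sapiens), read by fluorescence (a lower number here means a stronger inhibitor, a higher number a weaker inhibitor), the lowest of the three numbers on hand. For the measured compounds named here, compound 1 `FC(F)(F)c1ccccc1-c1nc(NCc2ccc(-c3cncnc3)cc2)c2ccccc2n1` gives 3000 nM in this assay, and compound 2 `FC(F)(F)c1ccccc1-c1nc(NCc2ccc(C3CCCCC3)cc2)c2ccccc2n1` gives 9800 nM; the only single-point step among them, a 3.3-fold higher number from compound 1 to compound 2 (0.51 log units; beyond the scatter), replaced an aromatic ring with a saturated carbocycle at a different position and weakened inhibition modestly.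

Compound 4 `c1cncc(-c2ccc(CNc3nc(C4CCCC4)nc4ccccc34)cc2)c1` differs from compound 3 by cyclopentyl in place of 2-ethylphenyl on an aromatic carbon. Going by the values given here, no measured pair tests this change at this position, so the expectation can rest only on the loose analogy that the one aromatic-to-saturated swap, a 3.3-fold higher number from compound 1 to compound 2 (0.51 log units; beyond the scatter), weakened inhibition, while here the entering group is also smaller than the one it replaces. On that basis compound 4 is expected to show a step of a 3.2-fold higher number from compound 3 to compound 4 (0.51 log units; beyond the scatter), toward a higher number, beyond the scatter but not large. Compound 4 is therefore estimated at 2500 nM in this assay, with a plausible range from 800 nM to 8000 nM.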

Compound 4, half-maximal inhibitory concentration: "not active" (no number reported)
For compound 4 the study gives words and no number; no gap can be computed for the estimate.
By their numbers in this assay, from the lowest: compound 3; then compound 1; then compound 2.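

In this assay, for the compounds shown here, compound 4 is reported only as "not active", with no number, so no step from compound 3 to compound 4 can be read. No measurement shown bears on why. The compounds shown leave open how large, in numbers, the effect of cyclopentyl in place of 2-ethylphenyl is.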